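This account rests on a few compounds, and the source may have more. Where it says the series, first, only, none or still open, it means among the compounds named here.

Compound 1 `O=C1C=C(NC2CCCCC2)C(=O)c2c1nc1n2[C@H]2OC[C@@H](O)[C@H]2OC1` carries a cyclohexylamino group on the shared core. In a functional assay on MCF7 cells (Homo sapiens) for inhibition, read by sulforhodamine B assay (a lower number here means a stronger inhibitor, a higher number a weaker inhibitor), compound 1 stops at the limit > 8000 nM, a boundary of the test rather than a number. Of the three values gathered, compound 1 is one of two that end at a limit. The other belongs to compound 2 `CCOc1ccccc1NC1=CC(=O)c2nc3n(c2C1=O)[C@H]1OC[C@@H](O)[C@H]1OC3`, which in this assay also reaches only a limit, > 4000 nM. Among the measured compounds shown here, compound 3 `CCOc1ccc(NC2=CC(=O)c3nc4n(c3C2=O)[C@H]2OC[C@@H](O)[C@H]2OC4)cc1` is the sole compound with a number, giving 1430 nM in this assay. The steps of an at least 5.5-fold lower number from compound 1 to compound 3 (0.74 log units; beyond the scatter) and an at least 2.7-fold lower number from compound 2 to compound 3 (0.44 log units; beyond the scatter) both lie beyond the scatter, whereas the step that the two limits leave unreadable from compound 1 to compound 2 cannot be read because the limit of > 8000 nM in this assay, at which 1 of the 3 values shown sits, and the limit of > 4000 nM in this assay, at which 1 of the 3 values shown sits, cap both ends. Compound 4 `O=C1C=C(N2CCCC2)C(=O)c2c1nc1n2[C@H]2OC[C@@H](O)[C@H]2OC1` differs from compound 1 by pyrrolidin-1-yl in place of cyclohexylamino on a double-bonded ring carbon. For the measured compounds named here, none of the measured steps exchanges the cyclohexylamino group for a ring joined through its nitrogen, so no measured step bears directly on this change, and the starting point is itself only a limit. The expected step is therefore a step that the limit leaves unreadable from compound 1 to compound 4, not readable beyond the scatter. Compound 4 is estimated at 12000 nM, within 3000 nM to 40000 nM, most likely again reported only as a limit.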

Compound 4, half-maximal inhibitory concentration: > 16000 nM
Compound 4: only a limit was reported; the forecaster's own chance of this, stated with the estimate: 65%; middle value at least 1.3-fold (0.12 log units) from the limit.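

In this assay compound 4 gives > 16000 nM, which is a limit. Compound 1 also ends at a limit, so no step can be read between compound 1 and compound 4. The compounds shown leave open whether pyrrolidin-1-yl and cyclohexylamino differ at all on the shared core.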